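Pyrrol-1-yl to Pyrazol-1-yl: Expecting Compound 4

The source may hold more compounds than are shown below. What is called first, only, known or untested is meant among the compounds shown, and "the series" means these compounds.

Three compounds have been measured in an assay on HEK293 cells for displacement of a labelled ligand from growth hormone secretagogue receptor type 1 (Homo sapiens), with a stated time of 60 min; a lower number here means a stronger inhibitor, a higher number a weaker inhibitor:

compound 1, `CS(=O)(=O)c1ccc2sc(NC(=O)NC(=O)c3ccccc3Cl)nc2c1`: 4700 nM
compound 2, `CN1CCN(CCCS(=O)(=O)c2ccc3nc(NC(=O)NC(=O)c4cc(-n5cccc5)ccc4Cl)sc3c2)CC1`: 0.15 nM
compound 3, `CS(=O)(=O)c1ccc2nc(NC(=O)NC(=O)c3ccccc3Cl)sc2c1`: 120 nM

Compound 2 holds the lowest number of the three. Its nearest neighbour is compound 3, which stands far beyond the scatter above it, and compound 1 lies further still. Among the compounds with values here, no two measured compounds differ in one place only, so no single step can be read off as a guide.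

Compound 4, `CN1CCN(CCCS(=O)(=O)c2ccc3nc(NC(=O)NC(=O)c4cc(-n5cccn5)ccc4Cl)sc3c2)CC1`, differs from compound 2 in one place: 1H-pyrazol-1-yl in place of 1H-pyrrol-1-yl on an aromatic carbon

Within the data shown here, the change swaps one five-membered aromatic ring for another of the same heavy-atom count, and nothing among the measured compounds speaks to it directly. A small step is expected in this assay , at most a modest weakening, quite possibly none beyond the scatter. Compound 4 is therefore expected to give 0.3 nM, in the range 0.08 nM to 1.5 nM. The step expected a 2.0-fold higher number from compound 2 to compound 4 (0.30 log units; within the scatter) is accordingly slight.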

Compound 4, half-maximal inhibitory concentration: 0.67 nM
Compound 4: the middle estimate sits 2.2-fold (0.35 log units) below what was measured; measured number inside the range.
By their numbers in this assay, from the lowest: compound 2; then compound 4; then compound 3; then compound 1.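

In this assay, the swap gives a 4.5-fold higher number from compound 2 to compound 4 (0.65 log units; beyond the scatter), the first single change read at this position, on an aromatic carbon para to a chloro group and meta to a large group. It shows that the position distinguishes between two five-membered aromatic rings of the same heavy-atom count: 1H-pyrazol-1-yl, with one more ring nitrogen and one more hydrogen-bond acceptor, gives a modestly higher number than 1H-pyrrol-1-yl while compound 4 stays at 0.67 nM. Nothing available explains why the number rises.

As far as these compounds go, what a 1H-imidazol-1-yl ring, a phenyl ring or a simple amine would give at this position remains open. So does whether the same swap would produce a step of this size in a compound without the side chain that compound 2 and compound 4 share.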